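Chalcone-like series: amino replaces trifluoromethyl on the aryl ketone

The source may report more compounds than this note shows. Statements on the series, on what has been measured and on what is new or still open speak of the compounds shown alone.

Two members of this series have been measured. Compound 1 `O=C(/C=C/C1=Cc2ccccc2OC1)c1ccccc1Br` and compound 2 `O=C(/C=C/C1=Cc2ccccc2OC1)c1ccc(C(F)(F)F)cc1` share the same core and differ only in the substituent on the aryl ketone. In a functional assay on the whole organism for inhibition, with Mus musculus as the target, with a stated time of 1 h, at a dose of 30 mg/kg by the intraperitoneal route (a higher number here means more inhibition at the dose given (going by the name of the read-out), a lower number less inhibition), compound 1 gives 56.6%. In this assay compound 2 gives 75.5%. Compound 2 therefore stands highest of the two numbers, with compound 1 as its nearest neighbour, lower by a margin beyond the usual scatter.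

Compound 3 `Nc1ccc(C(=O)/C=C/C2=Cc3ccccc3OC2)cc1` is the next member and has not yet been measured in this assay. Its structural change from compound 2 is amino in place of trifluoromethyl on an aromatic carbon. Among the measured compounds shown here, no measured pair covers a change of this kind, so the direction of the step is not fixed by the data. The change is large in kind, and a downward step is expected, of a size that may not clear the scatter; the expected step is a number 17.5 percentage points lower from compound 2 to compound 3 (beyond the scatter). Compound 3 is estimated to give 58% in this assay, with a range from 30% to 80%.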

Compound 3, a percentage reported as inhibition, in the whole organism at one dose (the size of the read-out at that dose, not a potency): 52.6%
Compound 3: middle estimate off by 5.4 percentage points, on the high side, within the range that was stated.
By their numbers in this assay, from the lowest: compounds 3 and 1 (each within the scatter of the next); then compound 2.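

In this assay, among the compounds shown here, amino in place of trifluoromethyl on an aromatic carbon, para to a large group, gives a number 22.9 percentage points lower from compound 2 to compound 3 (beyond the scatter) and is the first single change at this position that can be read directly, showing that the read-out responds to the group placed there. The change of 4-aminophenyl in place of 2-bromophenyl on a carbonyl carbon gives a number 4 percentage points lower from compound 1 to compound 3 (within the scatter) and therefore does not separate these two aryl ketones, leaving the 4-(trifluoromethyl)phenyl member of compound 2 apart from both among the three compounds shown. No measurement on these compounds bears on what lies behind either step.

From the compounds shown here alone, whether a methoxy group, a nitrile, a chlorine atom or a dimethylamino group at this position would read closer to compound 2 or to compound 3 remains open, and so does whether the step follows the departure of trifluoromethyl or the arrival of amino. With a single dose and a single time point, the figures also leave open how the compounds would rank at other doses or times.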